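The compounds below may be only part of what the source reports. "The series", "measured", "known", "first", "only" and "open" are said of these compounds alone.

Series notes. All four compounds share a core carrying two aziridin-1-yl groups; the side chains differ. Compound 1 `CN(C)C(=O)OCCC1=C(N2CC2)C(=O)C(CCOC(=O)N(C)C)=C(N2CC2)C1=O` carries two carbamate-terminated chains, and in a functional assay on L1210 cells (Mus musculus), with a stated time of 12 days (a lower number here means a less potent compound, a higher number a more potent compound, by a factor of ten per unit of this negative logarithm), compound 1 gives 5.16. Compound 2 `CCC(OC)C1=C(N2CC2)C(=O)C(C)=C(N2CC2)C1=O` carries a 1-methoxypropyl group and a methyl group, and in this assay compound 2 gives 5.68. Compound 3 `COCCOC(COC(N)=O)C1=C(N2CC2)C(=O)C(C)=C(N2CC2)C1=O` carries a longer ether chain ending in a carbamate, and in this assay compound 3 gives 6.03.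

Of the three measured numbers, compound 2 holds the second highest. Compound 3 stands higher than compound 2 by a margin beyond the scatter, and compound 1 stands lower than compound 2, also beyond the scatter.

Compound 4 `CC1=C(N2CC2)C(=O)C(C(C)C)=C(N2CC2)C1=O` has not been measured in this assay. Relative to compound 2 the change is isopropyl in place of 1-methoxypropyl on a double-bonded ring carbon. Among the compounds with values here, no pair of measured compounds differs in only one place, so the size of this step cannot be read from a measured pair. The 1-methoxypropyl group in compound 2 gives 5.68, while the carbamate-bearing chain in compound 3 gives 6.03; trimming the chain to isopropyl is expected to bring no gain. Compound 4 is expected to give 5.5, within a range from 4.9 to 6.1. The expected step of a number 0.18 log units lower from compound 2 to compound 4 (within the scatter) is small and within the scatter.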

Compound 4, logarithm of the reciprocal of the active concentration, log(1/C): 5.6
For compound 4 the middle estimate is 0.10 log units below the measured one; measured number inside the range.
By their numbers in this assay, from the lowest: compound 1; then compounds 4 and 2 (each within the scatter of the next); then compound 3.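

In this assay, the exchange of 1-methoxypropyl for isopropyl on a double-bonded ring carbon gives the series its first comparison in one place only: the step is a number 0.08 log units lower from compound 2 to compound 4 (within the scatter) and so does not separate the two compounds. For this pair, the ether oxygen and the single hydrogen-bond acceptor of 1-methoxypropyl are therefore not required to keep the number at this level, and the all-carbon isopropyl, the smaller of the two groups by heavy atoms, serves equally well at this position with the methyl group and both aziridin-1-yl groups unchanged. Nothing in hand explains why the exchange leaves the reading where it is.

The steps linking compound 1 or compound 3 to the others cannot be read, as each of those compounds differs from the rest in more than one place, so the carbamate-bearing chains cannot be assigned a contribution of their own. Within the data shown here, whether this position stays as undemanding with a primary amine, a carboxylic acid or a much longer alkyl chain remains open, since the one readable step covers only two small side chains.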